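Swapping a methyl for a cyano on a potent Bcl-2 family binder

A few compounds are considered here, and "the series" means these few. Any claim that something is new, unique, unknown or untested is made for them only; others in the source may bear on it.

The measure used here is an assay on isolated protein for displacement of a labelled ligand from Bcl2-associated agonist of cell death (Homo sapiens), read by fluorescence polarization; on this read-out higher numbers stand for weaker inhibition and lower numbers for stronger inhibition. Compound 1, with the structure `CN(C)CC[C@H](CSc1ccccc1)Nc1ccc(S(=O)(=O)NC(=O)c2ccc(N3CCN(CC4=C(c5ccc(Cl)cc5)CCC(C)(C)C4)CC3)cc2)cc1[N+](=O)[O-]`, gives in this assay a value of 1.4 nM. Compound 2, with the structure `Cc1cc(S(=O)(=O)NC(=O)c2ccc(N3CCN(Cc4ccccc4-c4ccc(Cl)cc4)CC3)cc2)ccc1N[C@H](CCN(C)C)CSc1ccccc1`, is reported in this assay only as < 1 nM, which is a limit of the assay rather than a number. This is the limit of < 1 nM in this assay, at which 1 of the 2 values shown sits, so for compound 2 only a boundary is known, not where within it the true value sits. Compound 3, with the structure `CN(C)CC[C@H](CSc1ccccc1)Nc1ccc(S(=O)(=O)NC(=O)c2ccc(N3CCN(Cc4ccccc4-c4ccc(Cl)cc4)CC3)cc2)cc1C#N`, differs from compound 2 in one spot: cyano in place of methyl on an aromatic carbon. Among the compounds with values here, no step between two fully measured compounds is available to calibrate this change, so the expectation rests on the values shown alone. Since compound 2 already sits at a limit, the step of a number no lower from compound 2 to compound 3 (the limit leaves the size open) is expected to be small, with no clear direction beyond the usual scatter. For compound 3 the value in this assay is estimated at 1 nM, within a range from 0.3 nM to 3 nM, with a fair chance that the assay again reports only a limit.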

Compound 3, inhibition constant: < 1 nM
Compound 3 ended at the assay's limit (the forecaster's own chance of this, stated with the estimate: 50%); the middle value sits exactly at the limit.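

In this assay compound 3 gives < 1 nM, a limit of the assay and not a number. Compound 2 is held by the same limit, so no step from methyl to cyano can be read between these two compounds, because both stop at one boundary: the limit of < 1 nM in this assay, at which 2 of the 3 values shown sit.

The compounds shown leave open whether cyano in place of methyl changes binding at all, and if so in which direction and by how much.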